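Swapping the amide for an ester on a shared core

The compounds below may be only part of what the source reports. "The series", "measured", "known", "first", "only" and "open" are said of these compounds alone.

Compounds with measured values:
- compound 1, `CSc1nc(-c2cccc(O)c2)c2c(N)c(C(=O)NC(C)(C)C)sc2n1`: 11.2%
- compound 2, `COc1cccc(-c2nc(SC)nc3sc(C(=O)NCc4ccccc4)c(N)c23)c1`: 3%

Both measured compounds share one core and differ in several places at once. In a functional assay on HEK293 cells for agonist activity at Thyrotropin receptor (Homo sapiens), read by cAMP accumulation (a lower number here means a smaller maximal response, a higher number a larger maximal response), compound 1 gives 11.2%, and in this assay compound 2 gives 3%. Compound 2 holds the lower of the two numbers, yet the gap to compound 1 lies within the usual scatter of this kind of measurement, so the two values cannot be told apart with confidence. Both sit far below the reference response.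

The next compound, compound 3, `CCOC(=O)c1sc2nc(SC)nc(-c3cccc(OC)c3)c2c1N`, is not yet measured. It differs from compound 2 in one place: ethoxy in place of benzylamino on a carbonyl carbon. For the measured compounds named here, no pair of measured compounds shows this change, so its effect is unknown here. Going by the values given here, with only two low values as a guide, and no contrast between them, the expected step of a number 5 percentage points higher from compound 2 to compound 3 (within the scatter) is none beyond the scatter. In this assay compound 3 is therefore expected to give 8%. For compound 3 the estimated range runs from 0% to 25%.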

Compound 3, largest response reached (reported as efficacy), in percent of the reference or control that the assay uses: 1.5%
Compound 3: the middle estimate sits 6.5 percentage points above what was measured; measured number inside the range.
By their numbers in this assay, from the lowest: compounds 3, 2 and 1 (each within the scatter of the next).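

For the compounds shown here, the exchange of benzylamino for ethoxy on the carbonyl carbon gives a number 1.5 percentage points lower from compound 2 to compound 3 (within the scatter) in this assay, and this is the first comparison here in which only one place differs. Losing the aromatic ring and the hydrogen-bond donor of benzylamino, and gaining the hydrogen-bond acceptor of ethoxy, therefore leaves a reading that cannot be told apart from that of compound 2, so neither the ring nor the donor is shown to matter here. Both compounds sit so far below the reference response, however, that this single step says little about how the position would behave in a compound with a larger response, and no measurement shown offers an explanation for the outcome.

Going by these compounds, whether a carboxylic acid, or a small amine-derived amide such as methylamino on the same carbonyl carbon, would give a reading beyond the scatter remains open. Also open, on these data alone, is whether a longer chain in place of ethoxy, such as butoxy, would lift the response clearly above that of compound 3 in this assay on the shared core.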